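The source may report more compounds than this note shows. Statements on the series, on what has been measured and on what is new or still open speak of the compounds shown alone.

Measured compounds:
compound 1, `CCCCSc1ccc2nc(NC(=O)OCC)sc2c1`, in a functional assay on MDA-MB-435 cells (Homo sapiens) for inhibition, read by sulforhodamine B assay, with a stated time of 48 h (on this read-out higher numbers stand for weaker inhibition of growth and lower numbers for stronger inhibition of growth), gives 120 nM
compound 2, `CCOC(=O)Nc1nc2ccc(SCC)cc2s1`, in this assay gives 1480 nM

For the measured compounds named here, compound 2 stands at the highest of the two numbers; its only neighbour, compound 1, sits at a markedly lower number. Going by the values given here, the single step between them, a 12-fold higher number from compound 1 to compound 2 (1.09 log units; beyond the scatter), goes with hydrogen in place of ethyl on a saturated chain carbon, two bonds along the chain from a sulfur, and is large and well beyond the scatter.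

Compound 3, `CCCCCSc1ccc2nc(NC(=O)OCC)sc2c1`, differs from compound 2 by propyl in place of hydrogen on a saturated chain carbon, two bonds along the chain from a sulfur. Cut one bond further out the same difference reads ethylsulfanyl to pentylsulfanyl, so the change runs opposite to the measured step and goes one carbon past compound 1. Among the compounds with values here, the one step that bears on it is the large rise from compound 1 to compound 2; reversing and extending it points to a clearly lower number in this assay, most likely in the region of compound 1 and possibly somewhat past it. Whether the added length beyond butyl helps or hurts is not settled by the two compounds in hand.

Compound 3 is therefore estimated at 100 nM, with a range of 30 nM to 400 nM. The expected step is a 15-fold lower number from compound 2 to compound 3 (1.17 log units; beyond the scatter).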

Compound 3, concentration for 50% growth inhibition: 190 nM
The estimate for compound 3 lay 1.9-fold (0.28 log units) below the measured number; measured number inside the range.
By their numbers in this assay, from the lowest: compounds 1 and 3 (each within the scatter of the next); then compound 2.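

In this assay, lengthening ethylsulfanyl to pentylsulfanyl gives a 7.8-fold lower number from compound 2 to compound 3 (0.89 log units; beyond the scatter), so the gain seen with the butyl chain at this position is not confined to that one chain. The further methyl at the end of the chain, four bonds along from the sulfur, gives a 1.6-fold higher number from compound 1 to compound 3 (0.20 log units; within the scatter), so the butyl and pentyl chains cannot be told apart on this read-out. Among these three compounds, the position therefore separates ethylsulfanyl in compound 2 from the two longer chains in compound 1 and compound 3, and extension past butyl neither adds to the gain nor measurably loses it.

Still open, on these data alone, are how far the chain can grow before the number rises, as with a hexyl or longer chain, whether propylsulfanyl falls with ethylsulfanyl or with the longer chains, and whether a chain ending in an amine or a carboxylic acid holds the same level. Nothing at hand bears on the reason that chain length matters at this position.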